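Dihydropyridone series: aryl swap from compound 3 to compound 4

A few compounds are considered here, and "the series" means these few. Any claim that something is new, unique, unknown or untested is made for them only; others in the source may bear on it.

Working notes on a small set of compounds measured in an assay on HEK293 cells for inhibition of neurogenic locus notch homolog protein 1 (Homo sapiens), read by a luciferase reporter and resazurin assay, with a stated time of 16 h; a lower number here means a stronger inhibitor, a higher number a weaker inhibitor. Compound 1 `CC1=C(C(=O)OCC2CCN(C(=O)OC(C)(C)C)CC2)[C@@H](c2cccc(Br)c2)C2=C(CC(C)(C)CC2=O)N1` gives 2590 nM in this assay. Compound 2 `CC1=C(C(=O)OCc2cnccn2)C(c2cccc(Br)c2)C2=C(CC(C)(C)CC2=O)N1` gives 860 nM. Compound 3 `CC1=C(C(=O)OCC2CCN(C(=O)OC(C)(C)C)CC2)C(c2cc(Cl)cc(Cl)c2)C2=C(CC(C)(C)CC2=O)N1` gives 640 nM, the lowest of the three numbers: its nearest neighbour is compound 2, whose number is higher by a margin within the scatter, so no order between compound 2 and compound 3 is claimed; its furthest neighbour is compound 1, whose number is higher by a margin beyond the scatter.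

The next compound, compound 4 `CC1=C(C(=O)OCC2CCN(C(=O)OC(C)(C)C)CC2)C(c2ccc(Br)cc2F)C2=C(CC(C)(C)CC2=O)N1`, has not yet been measured. Its change from compound 3 is 4-bromo-2-fluorophenyl in place of 3,5-dichlorophenyl on a saturated ring carbon. Among the compounds with values here, no step between measured compounds isolates this change. Within the data shown here, the only guide is compound 1, which shares the rest of the structure apart from the aryl group and the drawn stereochemistry and gives 2590 nM, a weaker result than compound 3.

Compound 4 is therefore expected to come out somewhat weaker than compound 3, with the step of a 2.3-fold higher number from compound 3 to compound 4 (0.37 log units; beyond the scatter) estimated as modest and uncertain in size. The estimate for compound 4 in this assay is 1500 nM, with a range from 500 nM to 4500 nM.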

Compound 4, half-maximal inhibitory concentration: > 10000 nM
Compound 4 gave a limit, no number; the forecaster's own chance of this, stated with the estimate: 5%; middle value at least 6.6-fold (0.82 log units) from the limit.
By their numbers in this assay, from the lowest: compounds 3 and 2 (each within the scatter of the next); then compound 1. At a limit, above all of these: compound 4.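

In this assay compound 4 gives > 10000 nM, which is a limit of the assay and not a number. The series now has its first step that isolates a single change, and it is large: an at least 15-fold higher number from compound 3 to compound 4 (1.19 log units; beyond the scatter), on swapping 3,5-dichlorophenyl for 4-bromo-2-fluorophenyl on a saturated ring carbon, even though both groups have the same count of heavy atoms, one six-membered aromatic ring of carbon only, no hydrogen-bond donors or acceptors and no net charge, so these counts do not predict the outcome at this carbon. The size of this step is read from a limit and not from two numbers: the limit of > 10000 nM in this assay, at which 1 of the 4 values shown sits.

The compounds shown do not separate the contributions of the bromine and the fluorine of 4-bromo-2-fluorophenyl, nor those of the two chlorines of 3,5-dichlorophenyl, and they give no reason for the loss. Also open, on these data alone, is how this carbon responds to an unsubstituted phenyl, a methoxyphenyl or a phenyl bearing a carboxylic acid, and whether the same aryl swap has a comparable effect with the pyrazinylmethyl ester of compound 2 in place of the ester carried by compound 3.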